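The source may report more compounds than this note shows. Statements on the series, on what has been measured and on what is new or still open speak of the compounds shown alone.

In an assay on CHO cells for displacement of a labelled ligand from transmembrane domain-containing protein TMIGD3 (Homo sapiens) (on this read-out higher numbers stand for weaker inhibition and lower numbers for stronger inhibition), compound 2 `O=c1oc2c(O)cccc2cc1-c1cccs1` gives 1430 nM, the lowest of the three numbers recorded. Compound 1 `CC(=O)Oc1cccc2cc(-c3ccsc3)c(=O)oc12`, which also bears thiophen-3-yl, gives 1820 nM, within the scatter of compound 2. Compound 3 `O=c1oc2c(O)c(O)ccc2cc1-c1cccs1` gives 4830 nM; the step from compound 2 to compound 3 is a 3.4-fold higher number from compound 2 to compound 3 (0.53 log units; beyond the scatter). Compound 4 `O=c1oc2c(O)cccc2cc1-c1ccsc1` differs from compound 2 by thiophen-3-yl in place of thiophen-2-yl on an aromatic carbon. Among the measured compounds shown here, no measured step isolates this change; the only guide is that compound 1, carrying thiophen-3-yl, sits within the scatter of compound 2 in this assay, so no step beyond the scatter is expected. The expected step from compound 2 to compound 4 is a 1.1-fold higher number from compound 2 to compound 4 (0.05 log units; within the scatter). Compound 4 is therefore estimated at 1600 nM, with a range from 700 nM to 3600 nM.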

Compound 4, inhibition constant: 2870 nM
The estimate for compound 4 lay 1.8-fold (0.25 log units) below the measured number; the range from low to high includes it.
By their numbers in this assay, from the lowest: compounds 2, 1, 4 and 3 (each within the scatter of the next, the first and the last beyond it).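

In this assay, among the compounds shown here, a comparison the earlier compounds did not offer, thiophen-3-yl in place of thiophen-2-yl on this aromatic carbon gives a 2.0-fold higher number from compound 2 to compound 4 (0.30 log units; within the scatter) and so is not separated from the scatter. With thiophen-3-yl kept, hydrogen in place of acetyl on the oxygen gives a 1.6-fold higher number from compound 1 to compound 4 (0.20 log units; within the scatter) and is likewise not resolved. No measurement given here accounts for either step. Still open, as far as these compounds go, is whether a phenyl ring, a pyridine ring or an amine on this carbon would move the number beyond the scatter.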